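A few compounds are considered here, and "the series" means these few. Any claim that something is new, unique, unknown or untested is made for them only; others in the source may bear on it.

Values so far in an ADME assay on BHK-21 cells (Mesocricetus auratus) for cytotoxicity, read by MTT assay, with a stated time of 72 h; a lower number here means that less compound is tolerated, a higher number that more compound is tolerated:
- compound 1 `NS(=O)(=O)c1ccc(N2N=C(c3ccc(Oc4ccccc4)cc3)CC2c2cccc(F)c2)cc1` gives 10000 nM
- compound 2 `NS(=O)(=O)c1ccc(N2N=C(c3ccc(OCc4ccccc4)cc3)CC2c2cccc(Cl)c2)cc1` gives 45000 nM
- compound 3 `NS(=O)(=O)c1ccc(N2N=C(c3ccc(OCc4ccccc4)cc3)CC2c2cccc(F)c2)cc1` gives 9000 nM

Compound 1 lies within the scatter of compound 3 and well short of compound 2, which has the highest number of the three. Next comes compound 4 `NS(=O)(=O)c1ccc(N2N=C(c3ccc(Oc4ccccc4)cc3)CC2c2ccccc2F)cc1` with 2-fluorophenyl in place of 3-fluorophenyl on a saturated ring carbon and nothing else altered. Among the compounds with values here, no measured step moves the fluorine. The closest guide is a 5.0-fold lower number from compound 2 to compound 3 (0.70 log units; beyond the scatter) for a modest change on that same ring, while a 1.1-fold lower number from compound 1 to compound 3 (0.05 log units; within the scatter) concerns another part of the molecule. In this assay no step beyond the scatter is therefore expected, and no direction can be favoured. The expected step is no change at the digits printed from compound 1 to compound 4 (within the scatter) on this estimate. For compound 4 the estimated value is 10000 nM with an expected range of 4000 nM to 25000 nM in repeat measurements.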

Compound 4, half-maximal cytotoxic concentration: 32000 nM
The estimate for compound 4 lay 3.2-fold (0.51 log units) below the measured number; the measured number lies above the stated range.
By their numbers in this assay, from the lowest: compounds 3 and 1 (each within the scatter of the next); then compounds 4 and 2 (each within the scatter of the next).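

In this assay the place of the fluorine on this ring matters: 2-fluorophenyl in place of 3-fluorophenyl gives a 3.2-fold higher number from compound 1 to compound 4 (0.51 log units; beyond the scatter), although the group keeps the same atoms. The earlier steps shown here showed a change of halogen on this ring, not a change in the halogen's place. Nothing available here gives a reason for this step.

Still open, going by these compounds, is whether the same shift holds with benzyl rather than phenyl on the oxygen. Also open, on these data alone, is how an amine or a methoxy group on this ring would compare with either fluorine.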